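Aryl swap on the ring nitrogen of compound 2

This account rests on a few compounds, and the source may have more. Where it says the series, first, only, none or still open, it means among the compounds named here.

Three compounds of the shared core have been run in a functional assay on HCT-116 cells (Homo sapiens) for antiproliferative activity, read by MTT assay, with a stated time of 48 h; on this read-out higher numbers stand for weaker inhibition and lower numbers for stronger inhibition. Compound 1 `COc1ccc(-n2nncc2CN2C(=O)C3(C(C#N)=C(N)Oc4c3c3nc5ccccc5nc3c3ccccc43)c3ccccc32)cc1` carries a 4-methoxyphenyl on the aromatic nitrogen. In this assay compound 1 gives only a limit, > 50000 nM. Compound 2 `N#CC1=C(N)Oc2c(c3nc4ccccc4nc3c3ccccc23)C12C(=O)N(Cc1cnnn1-c1ccc([N+](=O)[O-])cc1)c1ccccc12` has nitro in place of methoxy on an aromatic carbon. In this assay compound 2 likewise gives only a limit, > 50000 nM. Compound 3 `Cc1cc(C)cc(-n2nncc2CN2C(=O)C3(C(C#N)=C(N)Oc4c3c3nc5ccccc5nc3c3ccccc43)c3ccccc32)c1` carries 3,5-dimethylphenyl on the aromatic nitrogen. In this assay compound 3 also returns a limit, > 50000 nM. The steps a step that the two limits leave unreadable from compound 1 to compound 2, a step that the two limits leave unreadable from compound 1 to compound 3 and a step that the two limits leave unreadable from compound 2 to compound 3 are therefore all of unreadable size; what unites them is the limit of > 50000 nM in this assay, at which 3 of the 3 values shown sit. Compound 2 thus stands at the assay limit, as do the two others.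

Compound 4 `N#CC1=C(N)Oc2c(c3nc4ccccc4nc3c3ccccc23)C12C(=O)N(Cc1cnnn1-c1cc(Cl)ccc1Cl)c1ccccc12` differs from compound 2 by 2,5-dichlorophenyl in place of 4-nitrophenyl on an aromatic nitrogen. The measured steps that bear on it are the aryl swaps on the same nitrogen, a step that the two limits leave unreadable from compound 1 to compound 3 and a step that the two limits leave unreadable from compound 2 to compound 3, both unreadable, so neither size nor direction can be taken from them, and nothing beyond the scatter is expected in this assay. Compound 4 is expected to return a limit as well, the step that the limit leaves unreadable from compound 2 to compound 4 being the formal expression of that expectation. The estimate for compound 4 is 60000 nM, with a range from 20000 nM to 200000 nM.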

Compound 4, half-maximal inhibitory concentration: > 50000 nM
Compound 4 was reported as a limit; the forecaster's own chance of this, stated with the estimate: 80%; the middle value lies beyond the limit too.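

In this assay compound 4 gives > 50000 nM, a limit. No new step can be read among compound 1, compound 2, compound 3 and compound 4: the limit of > 50000 nM in this assay, at which 4 of the 4 values shown sit.

The compounds shown leave open whether any aryl group on this aromatic nitrogen of the shared core gives a measurable value in this assay, and how these aryl groups rank against one another.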